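Pyridin-2-yl Hydrazone in a Weakly Cytotoxic Oxadiazole Series

A few compounds are considered here, and "the series" means these few. Any claim that something is new, unique, unknown or untested is made for them only; others in the source may bear on it.

Measured compounds:
Compound 1, `COc1ccccc1-c1nnc(-c2ccc(C(=O)N/N=C/c3cc(O)ccc3O)cc2)o1`, in an ADME assay on THP-1 cells (Homo sapiens) for cytotoxicity (on this read-out higher numbers stand for weaker inhibition and lower numbers for stronger inhibition), compound 1 gives 100000 nM.
Compound 2, `COc1ccccc1-c1nnc(-c2ccc(C(=O)N/N=C/c3cccnc3)cc2)o1`, in this assay compound 2 gives 167000 nM.
Compound 3, `COc1ccccc1-c1nnc(-c2ccc(C(=O)N/N=C/c3cccc(O)c3O)cc2)o1`, in this assay compound 3 gives 102000 nM.

Compound 3 holds the second highest of the three numbers. Its nearest neighbour is compound 1, separated by a 1.0-fold higher number from compound 1 to compound 3 (0.01 log units; within the scatter), and its furthest is compound 2, separated by a 1.6-fold lower number from compound 2 to compound 3 (0.21 log units; within the scatter). All three numbers therefore sit inside the usual scatter of one another, and none of the three can be called stronger or weaker than the others.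

Compound 4, `COc1ccccc1-c1nnc(-c2ccc(C(=O)N/N=C/c3ccccn3)cc2)o1`, has not yet been measured. It differs from compound 3 in one place: pyridin-2-yl in place of 2,3-dihydroxyphenyl on a carbon with a double bond to nitrogen.

Within the data shown here, two measured steps bear on this change. The step of a 1.7-fold higher number from compound 1 to compound 2 (0.22 log units; within the scatter) also exchanged a dihydroxyphenyl for a pyridinyl at the same position and stayed within the scatter, and the step of a 1.6-fold lower number from compound 2 to compound 3 (0.21 log units; within the scatter), the reverse exchange, likewise stayed within the scatter. Because the step of a 1.7-fold higher number from compound 1 to compound 2 (0.22 log units; within the scatter) shows no movement beyond the scatter, compound 4 is expected to follow the same pattern, so that the step of a 1.3-fold higher number from compound 3 to compound 4 (0.11 log units; within the scatter) is expected to be small. Compound 4 is thus estimated at 130000 nM in this assay, with a range from 65000 nM to 260000 nM.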

Compound 4, half-maximal inhibitory concentration: 67000 nM
The estimate for compound 4 lay 1.9-fold (0.29 log units) above the measured number; the measured number falls inside the stated range.
By their numbers in this assay, from the lowest: compounds 4, 1, 3 and 2 (each within the scatter of the next, the first and the last beyond it).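

Among these compounds, the position on the carbon with a double bond to nitrogen now shows a step beyond the scatter in this assay for the first time: the exchange of pyridin-3-yl for pyridin-2-yl gives a 2.5-fold lower number from compound 2 to compound 4 (0.40 log units; beyond the scatter) and is a modest change. The exchange of either dihydroxyphenyl group for pyridin-2-yl stays within the scatter, with a 1.5-fold lower number from compound 3 to compound 4 (0.18 log units; within the scatter) and a 1.5-fold lower number from compound 1 to compound 4 (0.17 log units; within the scatter) as the two steps, so among these four compounds only the two pyridinyl groups are set apart, and neither is set apart from either dihydroxyphenyl group. Nothing available explains the difference between pyridin-2-yl and pyridin-3-yl.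

The compounds shown leave open whether a pyridin-4-yl group or a simple unsubstituted phenyl ring at this position would fall with compound 4, with compound 2 or elsewhere. They also leave open whether the gap between the two pyridinyl groups would persist on a core carrying an ethoxy group or a carboxylic acid in place of the methoxy group, since every compound here shares the same core.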